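The source may hold more compounds than are shown below. What is called first, only, known or untested is meant among the compounds shown, and "the series" means these compounds.

Of the compounds shown here, three sharing one core have been measured in an assay on Sf9 cells for inhibition of protein deacetylase HDAC6 (Homo sapiens), read by fluorescence, with a stated time of 40 min; on this read-out higher numbers stand for weaker inhibition and lower numbers for stronger inhibition. Compound 1 `COc1ccc(-n2nc(-c3ccccc3)nc2CNc2ccc(C(=O)NO)cc2)cc1`, which carries a 4-methoxyphenyl on the aromatic nitrogen, gives 127 nM. Compound 2 `O=C(NO)c1ccc(NCc2nc(-c3ccccc3)nn2-c2ccc(Br)cc2)cc1`, with a 4-bromophenyl in that place, gives 1730 nM, a change of a 14-fold higher number from compound 1 to compound 2 (1.13 log units; beyond the scatter). Compound 3 `O=C(NO)c1ccc(NCc2nc(-c3ccccc3)nn2-c2cccc(Cl)c2)cc1`, with a 3-chlorophenyl there, gives 678 nM and so stands second highest of the three, closer to compound 2 than to compound 1: the step of a 2.6-fold lower number from compound 2 to compound 3 (0.41 log units; beyond the scatter) is modest, while a 5.3-fold higher number from compound 1 to compound 3 (0.73 log units; beyond the scatter) is larger.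

Compound 4 `O=C(NO)c1ccc(NCc2nc(-c3ccccc3)nn2-c2ccc(F)cc2)cc1` differs from compound 3 in one place: 4-fluorophenyl in place of 3-chlorophenyl on an aromatic nitrogen. Going by the values given here, the steps that bear on this are the two involving a change of the group on that aromatic nitrogen, a 5.3-fold higher number from compound 1 to compound 3 (0.73 log units; beyond the scatter) and a 2.6-fold lower number from compound 2 to compound 3 (0.41 log units; beyond the scatter), both beyond the scatter but neither dramatic. Because compound 2 sits at 1730 nM and compound 1 at 127 nM, compound 4 is expected to fall between them, and the step of a 1.1-fold lower number from compound 3 to compound 4 (0.05 log units; within the scatter) is estimated to stay within the scatter. The estimate for compound 4 in this assay is 600 nM, with a range from 200 nM to 1800 nM.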

Compound 4, half-maximal inhibitory concentration: 274 nM
Compound 4: the middle estimate sits 2.2-fold (0.34 log units) above what was measured; measured number inside the range.
By their numbers in this assay, from the lowest: compound 1; then compound 4; then compound 3; then compound 2.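

Keeping the phenyl on the aromatic nitrogen and changing only the group on its aromatic carbon, fluoro in place of bromo gives a 6.3-fold lower number from compound 2 to compound 4 (0.80 log units; beyond the scatter), so the identity of the halogen alone clearly moves the number. Fluoro brings the series closer to the methoxy of compound 1, but not level with it, at a 2.2-fold higher number from compound 1 to compound 4 (0.33 log units; beyond the scatter), while the change from 3-chlorophenyl to 4-fluorophenyl gives a 2.5-fold lower number from compound 3 to compound 4 (0.39 log units; beyond the scatter). No measurement shown here explains these differences.

Compound 3 and compound 4 differ both in the halogen and in where it sits on the phenyl, so these two changes cannot be separated here. From the compounds shown here alone, how a methyl, an amine or a nitrile in place of the fluoro would read also remains open.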